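A few compounds are considered here, and "the series" means these few. Any claim that something is new, unique, unknown or untested is made for them only; others in the source may bear on it.

Measured compounds:
- compound 1 `CC(c1ccc(N(CCCCN(C)C)C(=O)O)cc1)n1nc(-c2ccc(F)cc2)c2ccccc2c1=O`; in an ADME assay on Huh-7 cells (Homo sapiens) for cytotoxicity, read by MTT assay, with a stated time of 48 h (a lower number here means that less compound is tolerated, a higher number that more compound is tolerated), compound 1 gives 15200 nM
- compound 2 `CN(C)CCCCC(=O)Nc1ccc(CN2N=C(c3ccc(F)cc3)C3C=CC=CC3C2=O)cc1`; in this assay compound 2 gives 77700 nM
- compound 3 `CN(C)CCCCOC(=O)Nc1ccc(Cn2nc(-c3ccc(C(F)(F)F)cc3)c3ccccc3c2=O)cc1`; in this assay compound 3 gives 3360 nM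

Compound 3 stands lowest of the three numbers in this assay: the nearest, compound 1, lies beyond the scatter above it, and compound 2 further still. No two of these compounds differ in a single place, so no step among them can be read as a cause.

Compound 4 `CN(C)CCCCOC(=O)Nc1ccc(Cn2nc(-c3ccccc3C(F)(F)F)c3ccccc3c2=O)cc1` is not yet measured. The change from compound 3 is 2-(trifluoromethyl)phenyl in place of 4-(trifluoromethyl)phenyl on an aromatic carbon, a rearrangement of the same atoms. Nothing among the three measured compounds shows what moving the trifluoromethyl around the phenyl does in this assay; compounds 1 and 2 differ from compound 3 in several places at once. For the measured compounds named here, with no comparable step on hand, no step beyond the scatter is expected from compound 3 to compound 4, and the estimate stays close to compound 3 with a wide range. Compound 4 is estimated at 4000 nM, between 1500 nM and 12000 nM, which amounts to an expected step of a 1.2-fold higher number from compound 3 to compound 4 (0.08 log units; within the scatter).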

Compound 4, half-maximal cytotoxic concentration: 35700 nM
Beside the measured number, compound 4's estimate is 8.9-fold (0.95 log units) below it; measured number above the stated range.
By their numbers in this assay, from the lowest: compound 3; then compound 1; then compound 4; then compound 2.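

In this assay, for the compounds shown here, the move of the trifluoromethyl gives an 11-fold higher number from compound 3 to compound 4 (1.03 log units; beyond the scatter), the first step that can be read from a change in one place. The two compounds hold the same atoms, so how the substituent is placed on the phenyl, and not which atoms are present, separates 2-(trifluoromethyl)phenyl from 4-(trifluoromethyl)phenyl on this aromatic carbon of the shared core. Nothing measured on hand gives a reason for a step of this size.

Open, going by these compounds, is how a 2-chlorophenyl or a 2-methoxyphenyl at this place would stand, and whether an unsubstituted phenyl would lie nearer compound 3 or compound 4. Also open, on these data alone, is whether the same step appears when the dimethylamino chain gives way to a shorter chain or a piperidine.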